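Adding a Second Fluoro to the Benzoyl Ring

A few compounds are considered here, and "the series" means these few. Any claim that something is new, unique, unknown or untested is made for them only; others in the source may bear on it.

Measured so far in a functional assay on MCF7 cells (Homo sapiens) for inhibition, read by MTT assay, with a stated time of 72 h; on this read-out lower numbers stand for stronger inhibition and higher numbers for weaker inhibition:
Compound 1 `CN(C(=O)NC(=O)c1c(F)cccc1F)c1nc(C(F)(F)F)c(C(=O)N/N=C/c2cccc(C(F)(F)F)c2)s1`, 21.8 ug/mL.
Compound 2 `CN(C(=O)NC(=O)c1c(Cl)cccc1Cl)c1nc(C(F)(F)F)c(C(=O)N/N=C/c2ccccc2C(F)(F)F)s1`, 6.24 ug/mL.
Compound 3 `CN(C(=O)NC(=O)c1ccccc1F)c1nc(C(F)(F)F)c(C(=O)N/N=C/c2ccccc2C(F)(F)F)s1`, 12.2 ug/mL.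

Compound 3 stands second highest of the three numbers; its gap to compound 1 and its gap to compound 2 both lie within the scatter. Compound 4 `CN(C(=O)NC(=O)c1c(F)cccc1F)c1nc(C(F)(F)F)c(C(=O)N/N=C/c2ccccc2C(F)(F)F)s1` differs from compound 3 by fluoro in place of hydrogen on an aromatic carbon. Among the measured compounds shown here, the one measured step that touches this part of the molecule, a 2.0-fold higher number from compound 2 to compound 3 (0.29 log units; within the scatter), stayed within the scatter, and compound 1, which already carries a 2,6-difluorophenyl on the carbonyl carbon, gives 21.8 ug/mL. Little movement is therefore expected: the estimated step of a 1.2-fold lower number from compound 3 to compound 4 (0.09 log units; within the scatter) is within the scatter. Compound 4 is expected to give about 10 ug/mL, with a range from 4 ug/mL to 25 ug/mL.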

Compound 4, half-maximal inhibitory concentration: 20.4 ug/mL
Beside the measured number, compound 4's estimate is 2.0-fold (0.31 log units) below it; the range from low to high includes it.
By their numbers in this assay, from the lowest: compounds 2, 3, 4 and 1 (each within the scatter of the next, the first and the last beyond it).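

In this assay, fluoro in place of hydrogen on the aromatic carbon leaves the number within the scatter (a 1.7-fold higher number from compound 3 to compound 4 (0.22 log units; within the scatter)). Among the compounds shown here, replacing both chloro atoms of the 2,6-dichlorophenyl with fluoro gives the first step on this ring that lies beyond the scatter, though a modest one (a 3.3-fold higher number from compound 2 to compound 4 (0.51 log units; beyond the scatter)), while 2-(trifluoromethyl)phenyl in place of 3-(trifluoromethyl)phenyl stays within it (a 1.1-fold lower number from compound 1 to compound 4 (0.03 log units; within the scatter)). Nothing available explains these steps. From the compounds shown here alone, what a methoxy group or an amine would do on this ring remains open.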